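Adding a bromo group to compound 2

The source may report more compounds than this note shows. Statements on the series, on what has been measured and on what is new or still open speak of the compounds shown alone.

Compound 1 `O=C(N/N=C/c1ccc(Br)cc1)Nc1ccc(Oc2ccnc3[nH]ccc23)c(F)c1` gives 1000 nM
Compound 2 `O=C(N/N=C/c1ccccc1)Nc1ccc(Oc2ccnc3[nH]ccc23)cc1` gives 750 nM

In a functional assay on HepG2 cells (Homo sapiens) for antiproliferative activity, read by MTT assay, with a stated time of 72 h (a higher number here means a weaker inhibitor, a lower number a stronger inhibitor), compound 2 gives 750 nM and compound 1 gives 1000 nM as its number. These two lie within the scatter of each other, so neither stands apart. Compound 3 `O=C(N/N=C/c1ccc(Br)cc1)Nc1ccc(Oc2ccnc3[nH]ccc23)cc1` is compound 2 with one change (bromo in place of hydrogen on an aromatic carbon): bromo in place of hydrogen on an aromatic carbon, phenyl to 4-bromophenyl. Going by the values given here, no measured pair shows this change alone. Compound 1 also carries the 4-bromophenyl group and gives 1000 nM as its number, so no large move is expected. In this assay the expected size of a 1.1-fold higher number from compound 2 to compound 3 (0.03 log units; within the scatter) is nothing beyond the scatter. For compound 3 the estimate is 800 nM (expected range 350 nM to 1800 nM).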

Compound 3, half-maximal inhibitory concentration: 1000 nM
For compound 3 the middle estimate is 1.3-fold (0.10 log units) below the measured one, and the stated range covers the measured number.
By their numbers in this assay, from the lowest: compounds 2, 1 and 3 (each within the scatter of the next).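

With single changes now readable, bromo in place of hydrogen on the aromatic ring, phenyl to 4-bromophenyl, gives in this assay a 1.3-fold higher number from compound 2 to compound 3 (0.12 log units; within the scatter) and stays within the scatter. Hydrogen in place of fluoro gives no change at the digits printed from compound 1 to compound 3 (within the scatter) and also stays within the scatter, so neither change separates these compounds. No measurement shown offers an explanation for these results.
Only hydrogen and bromo can be compared at this place on the ring. An amine or a carboxylic acid there remains an open question.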